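From methoxy to fluoro: a small step expected

The source may report more compounds than this note shows. Statements on the series, on what has been measured and on what is new or still open speak of the compounds shown alone.

Measured in a functional assay on HCC70 cells (Homo sapiens) for antiproliferative activity, read by crystal violet staining, with a stated time of 96 h; on this read-out higher numbers stand for an effect only at larger amounts of compound and lower numbers for an effect already at smaller amounts
compound 1 `O[C@@H]1[C@@H](O)[C@H](Oc2ccc3ccccc3c2)OC[C@H]1F` gives 37 uM
compound 2 `O[C@@H]1CO[C@@H](Oc2ccc3ccccc3c2)C[C@H]1O` gives 228 uM
compound 3 `CO[C@H]1[C@H](Oc2ccc3ccccc3c2)OC[C@@H](O)[C@@H]1O` gives 127 uM

Compound 3 sits within the scatter of compound 2, while compound 1 shows a lower number, beyond the scatter. Within the data shown here, compound 4 `O[C@@H]1[C@@H](F)[C@H](Oc2ccc3ccccc3c2)OC[C@H]1O` keeps the shared core but has fluoro in place of methoxy on a saturated ring carbon as its one change. Among the measured compounds shown here, the only measured step at this carbon, methoxy in place of hydrogen, is a 1.8-fold lower number from compound 2 to compound 3 (0.25 log units; within the scatter) and so gives no sign of a large effect. For the measured compounds named here, compound 1 also carries fluoro, but no measured step links it to the others. No step beyond the scatter is therefore expected in this assay for this swap. The estimate means a 1.3-fold lower number from compound 3 to compound 4 (0.10 log units; within the scatter) as the expected step. Compound 4 is expected at 100 uM with a range from 40 uM to 250 uM as its estimate.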

Compound 4, concentration for half-maximal effect: 22 uM
Beside the measured number, compound 4's estimate is 4.5-fold (0.66 log units) above it, and the stated range ends above it.
By their numbers in this assay, from the lowest: compounds 4 and 1 (each within the scatter of the next); then compounds 3 and 2 (each within the scatter of the next).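

In this assay, this saturated ring carbon proves sensitive to the group it carries: fluoro in place of methoxy gives a 5.8-fold lower number from compound 3 to compound 4 (0.76 log units; beyond the scatter), and fluoro in place of hydrogen gives a 10-fold lower number from compound 2 to compound 4 (1.02 log units; beyond the scatter). The methoxy step at this carbon stayed within the scatter, so only fluoro shows that a change here can move the number beyond it. Nothing available explains why fluoro has this effect. As far as these compounds go, whether chloro or an amine on this carbon would move the number as far remains open.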